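This account rests on a few compounds, and the source may have more. Where it says the series, first, only, none or still open, it means among the compounds named here.

Measured compounds:
compound 1 `O=C(Nc1cccc(-c2oc3cc(-c4ccc(F)cc4)ccc3c(=O)c2O)c1)c1ccc(C(F)(F)F)cc1` gives 7350 nM
compound 2 `CCc1ccc(C(=O)Nc2cccc(-c3oc4cc(-c5ccc(F)cc5)ccc4c(=O)c3O)c2)cc1` gives 13200 nM

Both numbers come from a functional assay on HCC1937 cells (Homo sapiens) for antiproliferative activity, read by CCK-8 assay, with a stated time of 72 h; a higher number here means a weaker inhibitor, a lower number a stronger inhibitor. Compound 2 has the higher of the two numbers, but the step of a 1.8-fold higher number from compound 1 to compound 2 (0.25 log units; within the scatter) lies within the scatter, so the two cannot be ranked. Compound 3 `Cc1cc(C)cc(C(=O)Nc2cccc(-c3oc4cc(-c5ccc(F)cc5)ccc4c(=O)c3O)c2)c1` differs from compound 2 by 3,5-dimethylphenyl in place of 4-ethylphenyl on a carbonyl carbon. Going by the values given here, no measured step changes the pattern of substituents on this ring in the same way; the only measured step, a 1.8-fold higher number from compound 1 to compound 2 (0.25 log units; within the scatter), concerns a different exchange and was small. Compound 3 is therefore expected to stay near compound 2, with a step of a 1.1-fold lower number from compound 2 to compound 3 (0.04 log units; within the scatter) of no size beyond the scatter. The estimate for compound 3 is 12000 nM, ranging from 5000 nM to 30000 nM.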

Compound 3, half-maximal inhibitory concentration: 4860 nM
Estimate against measurement, compound 3: 2.5-fold (0.39 log units) above; measured number outside the range, below it.
By their numbers in this assay, from the lowest: compounds 3, 1 and 2 (each within the scatter of the next, the first and the last beyond it).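

Going by these compounds alone, exchanging 4-ethylphenyl for 3,5-dimethylphenyl on a carbonyl carbon gives a 2.7-fold lower number from compound 2 to compound 3 (0.43 log units; beyond the scatter) in this assay, the first step at this position beyond the scatter, with the same atoms joined differently. The exchange from 4-(trifluoromethyl)phenyl gives a 1.5-fold lower number from compound 1 to compound 3 (0.18 log units; within the scatter), so those two cannot be ranked. Nothing measured here explains the difference between the two carbon arrangements.

The compounds shown leave open how a single methyl, a methoxy group or an amine on this ring would compare, and whether two substituents are needed to hold the number of compound 3.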